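Two stereocentres inverted on the side chain of compound 3

The source may report more compounds than this note shows. Statements on the series, on what has been measured and on what is new or still open speak of the compounds shown alone.

Compound 3 `CCCC[C@@](C)(OC)[C@H](O)/C=C/C1[C@H](O)CC(=O)[C@@H]1CCCCCCC(=O)OC` gives 0.0045 mg/kg in a functional assay on the whole organism (stomach) with Rattus norvegicus as the target (on this read-out lower numbers stand for an effect already at smaller amounts and higher numbers for an effect only at larger amounts of compound), the lowest number among the values shown. Compound 1 `CCCC[C@](C)(OC)[C@@H](O)/C=C/C1[C@H](O)CC(=O)[C@@H]1C/C=C\CCCC(=O)OC` gives 1.5 mg/kg in this assay. For compound 2 `CCCC[C@@](C)(OC)[C@@H](O)/C=C/C1[C@H](O)CC(=O)[C@@H]1CCCCCCC(=O)OC` this assay reports only a limit, > 1 mg/kg. The step of an at least 220-fold lower number from compound 2 to compound 3 (2.34 log units; beyond the scatter) is open-ended at one side because of the limit of > 1 mg/kg in this assay, at which 1 of the 3 values shown sits. Compound 4 `CCCC[C@](C)(OC)[C@@H](O)/C=C/C1[C@H](O)CC(=O)[C@@H]1CCCCCCC(=O)OC` is not yet measured; it differs from compound 3 thus: the two compounds have the same atoms and bonds; at least one stereo element is drawn with a configuration in one of them and without one in the other: 2 of 6 stereo elements differ; a stereocentre at a saturated chain carbon is drawn R in compound 3 and S in compound 4; a stereocentre at a saturated chain carbon is drawn R in compound 3 and S in compound 4. As a single inversion of this kind already moved the number greatly, a double inversion is expected to raise the number again, estimated as a 110-fold higher number from compound 3 to compound 4 (2.05 log units; beyond the scatter). Compound 4 is therefore estimated at 0.5 mg/kg in this assay, within a range from 0.05 mg/kg to 5 mg/kg.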

Compound 4, dose for 50% inhibition: > 3 mg/kg
Compound 4: only a limit was reported; the forecaster's own chance of this, stated with the estimate: 40%; middle value at least 6.0-fold (0.77 log units) away from the limit.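

Inverting the second stereocentre as well does not win back what the first inversion lost in this assay: the double inversion gives an at least 660-fold higher number from compound 3 to compound 4 (2.82 log units; beyond the scatter). The value of compound 4 is a limit, and the step between the two limits of compound 2 and compound 4 cannot be read. Against the unsaturated 5-(methoxycarbonyl)pent-1-en-1-yl chain, the data show an at least 2.0-fold higher number from compound 1 to compound 4 (0.30 log units; that floor lies within the scatter), so no difference can be claimed.

Still open, on these data alone, is what inverting only the other stereocentre does to compound 3. Also open, as far as these compounds go, is how a carboxylic acid in place of the methoxycarbonyl group would behave.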